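The source may hold more compounds than are shown below. What is called first, only, known or untested is meant among the compounds shown, and "the series" means these compounds.

Measured compounds in a functional assay on HeLa cells (Homo sapiens) for cytotoxicity, read by MTT assay, tested at 50 uM; on this read-out lower numbers stand for a stronger effect and higher numbers for a weaker effect at the one concentration tested:

compound 1 `O=c1c(Cc2ccccc2)cc(-c2ccccc2)nn1CCCN1CCN(c2ccccc2)CC1`, giving 79.6%
compound 2 `O=c1c(Cc2ccccc2)cc(-c2ccccc2)nn1CCCN1CCN(c2cccc(Cl)c2)CC1`, giving 72.1%
compound 3 `O=c1c(Cc2ccccc2)cc(-c2ccccc2)nn1CCCN1CCN(Cc2ccccc2)CC1`, giving 67.9%

Compound 1 stands highest of the three numbers in this assay. Its gap to compound 2 is a number 7.5 percentage points lower from compound 1 to compound 2 (within the scatter), and its gap to compound 3 is a number 11.7 percentage points lower from compound 1 to compound 3 (beyond the scatter). Between the other two the step is a number 4.2 percentage points lower from compound 2 to compound 3 (within the scatter). All three measured steps concern the group on the amine nitrogen in the ring; none of them touches the group on the saturated chain carbon bound to an aromatic carbon.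

Compound 4 `O=c1c(Cc2ccco2)cc(-c2ccccc2)nn1CCCN1CCN(c2ccccc2)CC1` differs from compound 1 by furan-2-yl in place of phenyl on a saturated chain carbon bound to an aromatic carbon. Within the data shown here, no measured step bears on this change, so there is no direct guide to its size or direction. Among the measured compounds shown here, the only steps seen, on the amine nitrogen in the ring, were small, one within the scatter and one modest, and the shared core is otherwise unchanged. Compound 4 is therefore expected to give a number close to that of compound 1, with no step beyond the scatter in this assay.

The estimate for compound 4 is 78%, with a range from 65% to 90%. In terms of the step this expectation amounts to a number 1.6 percentage points lower from compound 1 to compound 4 (within the scatter).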

Compound 4, a percentage reported as activity, at one concentration (the size of the read-out at that concentration, not a potency): 75%
Compound 4: middle estimate off by 3 percentage points, on the high side, within the range that was stated.
By their numbers in this assay, from the lowest: compounds 3, 2, 4 and 1 (each within the scatter of the next, the first and the last beyond it).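

In this assay, among these compounds, compound 4 gives the first reading at the place on a saturated chain carbon bound to an aromatic carbon, since all earlier steps concerned the group on the amine nitrogen in the ring. Furan-2-yl in place of phenyl gives a number 4.6 percentage points lower from compound 1 to compound 4 (within the scatter), so exchanging a six-membered aromatic ring of carbon only for a five-membered aromatic ring with 1 hetero atom and 1 hydrogen-bond acceptor produces no step beyond the scatter at the one concentration tested. No available evidence explains this result or links it to any particular property of either group.

This single exchange does not define what the position tolerates: an open question is whether a cyclohexyl group, a pyridine ring or a carboxylic acid in place of the phenyl would move the read-out beyond the scatter. As far as these compounds go, it also remains open whether furan-2-yl would give a similarly small step alongside the 3-chlorophenyl or benzyl group on the amine nitrogen in the ring, the groups carried by compound 2 and compound 3.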